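Aryl for Alkyl on the Ring Nitrogen

A few compounds are considered here, and "the series" means these few. Any claim that something is new, unique, unknown or untested is made for them only; others in the source may bear on it.

Of the compounds shown here, three sharing one core have been tested in an assay on HEK-293T cells for antagonist activity at vitamin D3 receptor (Homo sapiens), read by a luciferase reporter, with a stated time of 24 h; a higher number here means a weaker inhibitor, a lower number a stronger inhibitor. Compound 1 `CC(C)c1onc(-c2c(Cl)cccc2Cl)c1COc1ccc(-c2nc3cc(C(=O)O)ccc3n2C)cc1` gives 4410 nM, compound 2 `CC(C)c1onc(-c2c(Cl)cccc2Cl)c1COc1ccc(-c2nc3ccc(C(=O)O)cc3n2CC2CCCCC2)c(F)c1` gives 840 nM, and compound 3 `CC(C)c1onc(-c2c(Cl)cccc2Cl)c1COc1ccc(-c2nc3ccc(C(=O)O)cc3n2CC(C)(C)C)cc1` gives 861 nM. Compound 3 thus stands second highest of the three; its number and that of compound 2 lie within the scatter of each other, while compound 1 sits above both, beyond the scatter. Compound 1 differs from compound 3 in more than one place, so its higher number cannot be tied to the ring-nitrogen group alone. Compound 4 `CC(C)c1onc(-c2c(Cl)cccc2Cl)c1COc1ccc(-c2nc3ccc(C(=O)O)cc3n2-c2ccc(F)cc2)cc1` has not yet been measured and differs from compound 3 in one place: 4-fluorophenyl in place of neopentyl on an aromatic nitrogen. Among the measured compounds shown here, no measured pair shows this change, so its effect in this assay is open. Compound 4 is estimated at 1000 nM, with a range from 300 nM to 3500 nM. That estimate means a step of a 1.2-fold higher number from compound 3 to compound 4 (0.06 log units; within the scatter), expected to stay within the scatter.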

Compound 4, half-maximal inhibitory concentration: 2410 nM
Beside the measured number, compound 4's estimate is 2.4-fold (0.38 log units) below it; the range from low to high includes it.
By their numbers in this assay, from the lowest: compounds 2 and 3 (each within the scatter of the next); then compounds 4 and 1 (each within the scatter of the next).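

Among the compounds shown here, at the aromatic nitrogen, 4-fluorophenyl in place of neopentyl gives a 2.8-fold higher number from compound 3 to compound 4 (0.45 log units; beyond the scatter) in this assay, the first comparison in which only the group at this position changes. The group on this nitrogen therefore affects the number, and for this one pair, neopentyl, which has no ring, gives the stronger inhibitor. No available evidence accounts for the step. On these data alone, whether plain phenyl or benzyl on this nitrogen would fall nearer compound 3 or compound 4 remains open, as does whether the fluorine contributes to the step.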